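Series notes: benzyl in place of 5-methylfuran-2-yl

The compounds below may be only part of what the source reports. "The series", "measured", "known", "first", "only" and "open" are said of these compounds alone.

Measured so far:
compound 1 `Cc1ccc(-c2nc(N)c3nn(-c4ccccc4)cc3n2)o1` — an assay on CHO cells for displacement of a labelled ligand from adenosine receptor A3 (Homo sapiens), read by scintillation counting, with a stated time of 60 min; a lower number here means a stronger inhibitor, a higher number a weaker inhibitor: 147 nM
compound 2 `COc1ccccc1-n1cc2nc(-c3ccc(C)o3)nc(N)c2n1` — this assay: 297 nM

Among the measured compounds shown here, compound 2 stands at the highest of the two numbers measured so far. Its nearest neighbour is compound 1, and the step of a 2.0-fold higher number from compound 1 to compound 2 (0.31 log units; beyond the scatter) separates them, a difference reported as beyond the scatter.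

Compound 3 `COc1ccccc1-n1cc2nc(Cc3ccccc3)nc(N)c2n1` differs from compound 2 by benzyl in place of 5-methylfuran-2-yl on an aromatic carbon. For the measured compounds named here, no measured step covers this exchange; the single step measured, a 2.0-fold higher number from compound 1 to compound 2 (0.31 log units; beyond the scatter), concerns a methoxy at another position and does not bear on a change at this one. The expectation for compound 3 therefore rests only on the size of the exchange, a whole aromatic group replaced by another of different ring type and attachment, which is a larger structural change than the one already measured. A moderate shift is expected, more likely toward a higher number than a lower one, with wide uncertainty in both directions. Compound 3 is estimated at 800 nM in this assay, within 150 nM to 4000 nM. The expected step of a 2.7-fold higher number from compound 2 to compound 3 (0.43 log units; beyond the scatter) would thus exceed the scatter.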

Compound 3, inhibition constant: 405 nM
The estimate for compound 3 lay 2.0-fold (0.30 log units) above the measured number; the measured number falls inside the stated range.
By their numbers in this assay, from the lowest: compound 1; then compounds 2 and 3 (each within the scatter of the next).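

In this assay, benzyl in place of 5-methylfuran-2-yl on the aromatic carbon between two ring nitrogen atoms gives a 1.4-fold higher number from compound 2 to compound 3 (0.13 log units; within the scatter), so compound 2 and compound 3 cannot be told apart at this position. This pair shows that, with the methoxy-bearing core of compound 2 held constant, the position tolerates a change from a five-membered aromatic ring with 1 hetero atom to a six-membered aromatic ring of carbon only, and from 1 hydrogen-bond acceptor to 0 hydrogen-bond acceptors, without a change in the read-out that exceeds the scatter. No available evidence bears on why these two groups read alike.

This single exchange does not show how far that tolerance extends: a morpholine or other saturated amine, a carboxylic acid, or a longer chain such as phenethyl at the same carbon could give a different result. As far as these compounds go, it also remains open whether benzyl would read the same way on the core of compound 1, which carries hydrogen where compound 2 carries methoxy.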